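From thiazolyl to phenyl on a saturated ring carbon

A few compounds are considered here, and "the series" means these few. Any claim that something is new, unique, unknown or untested is made for them only; others in the source may bear on it.

In a toxicity assay on HepG2 2.2.15 cells (Homo sapiens) for cytotoxicity, read by CellTiter-Glo (a lower number here means that less compound is tolerated, a higher number that more compound is tolerated), compound 3 `O=C1CC(c2nccs2)CN1c1cnn2c1CN(C(=O)Nc1cc(F)c(F)c(F)c1)C(C1CC1)C2` gives 115000 nM, level with compound 1 `O=C1CC(C(F)(F)F)CN1c1cnn2c1CN(C(=O)Nc1cc(F)c(F)c(F)c1)C(C1CC1)C2` at 115000 nM. Together these are the highest of the three numbers, and compound 2 `O=C1c2ccccc2CN1c1cnn2c1CN(C(=O)Nc1cc(F)c(F)c(F)c1)C(C1CC1)C2` gives 38500 nM. The next compound, compound 4 `O=C1CC(c2ccccc2)CN1c1cnn2c1CN(C(=O)Nc1cc(F)c(F)c(F)c1)C(C1CC1)C2`, carries phenyl in place of 1,3-thiazol-2-yl on a saturated ring carbon, two ring bonds from the ring nitrogen: phenyl in place of 1,3-thiazol-2-yl on a saturated ring carbon. Of the measured steps, only no change at the digits printed from compound 1 to compound 3 (within the scatter) changes the group at this carbon, and it suggests little movement. The other two, a 3.0-fold lower number from compound 1 to compound 2 (0.48 log units; beyond the scatter) and a 3.0-fold higher number from compound 2 to compound 3 (0.48 log units; beyond the scatter), concern a different group that also holds a six-membered aromatic ring of carbon only, as phenyl does. They are a loose guide, but they leave room for a modest drop. A small move toward a lower number in this assay is therefore expected, with the estimated step being a 1.8-fold lower number from compound 3 to compound 4 (0.25 log units; within the scatter). For compound 4 the estimated value is 65000 nM, with an expected range of 28000 nM to 125000 nM.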

Compound 4, half-maximal cytotoxic concentration: 12800 nM
Beside the measured number, compound 4's estimate is 5.1-fold (0.71 log units) above it; measured number below the stated range.
By their numbers in this assay, from the lowest: compound 4; then compound 2; then compounds 1 and 3 (each within the scatter of the next).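

In this assay the saturated ring carbon proves sensitive to its group after all, with a 9.0-fold lower number from compound 3 to compound 4 (0.95 log units; beyond the scatter) and a 9.0-fold lower number from compound 1 to compound 4 (0.95 log units; beyond the scatter) even though trifluoromethyl and 1,3-thiazol-2-yl had left the number level. Of the three groups shown at this carbon, phenyl alone stands apart, on the side where less compound is tolerated. A six-membered aromatic ring of carbon only does not by itself fix the number, since a 3.0-fold lower number from compound 2 to compound 4 (0.48 log units; beyond the scatter) separates two groups that both hold one.

Nothing available here bears on why phenyl differs from the other two groups at this carbon. From the compounds shown here alone, whether the number follows the ring nitrogen and sulfur of the thiazole or something else remains open, and a pyridin-2-yl or a methyl at the same carbon would be needed to tell.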